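Halogen swap on the triazole-bound phenyl ring

The compounds below may be only part of what the source reports. "The series", "measured", "known", "first", "only" and "open" are said of these compounds alone.

For the measured compounds named here, compound 1 `O=c1[nH]cc(S(=O)(=O)Nc2ccccc2-c2cn(-c3ccc(F)cc3)nn2)c(=O)[nH]1` is the one measured compound with a numerical value: in a functional assay on A549 cells (Homo sapiens) for antiproliferative activity, read by MTT assay, with a stated time of 24 h (on this read-out lower numbers stand for stronger inhibition and higher numbers for weaker inhibition), compound 1 gives 6390 nM. Compound 2 `O=c1[nH]cc(S(=O)(=O)Nc2cccc(-c3cn(-c4ccccc4F)nn3)c2)c(=O)[nH]1` carries the same shared core, with the triazole attached to a different position of the aniline ring and a 2-fluorophenyl on the triazole nitrogen. For compound 2 only a limit is recorded in this assay, > 20000 nM, so its value is not a number (the limit of > 20000 nM in this assay, at which 1 of the 2 values shown sits). Going by the values given here, no step between two measured compounds can be computed here, and the two values show only that compound 1 lies inside the range while compound 2 sits at its edge.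

Compound 3 `O=c1[nH]cc(S(=O)(=O)Nc2cccc(-c3cn(-c4ccc(Cl)cc4)nn3)c2)c(=O)[nH]1` is not yet measured. It differs from compound 2 in one place: 4-chlorophenyl in place of 2-fluorophenyl on an aromatic nitrogen. The step from compound 2 to compound 3 is expected to be small or within the scatter, since the shared core and the aniline arrangement of compound 2 are kept, an at least 1.3-fold lower number from compound 2 to compound 3 (0.12 log units; that floor lies within the scatter). Compound 3 is estimated at 15000 nM, with a range from 5000 nM to 40000 nM in this assay.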

Compound 3, half-maximal inhibitory concentration: 1730 nM
The estimate for compound 3 lay 8.7-fold (0.94 log units) above the measured number; the whole stated range lies above it.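

This position on the aromatic nitrogen of the five-membered ring responds strongly in this assay: with the shared core and the aniline arrangement kept, 4-chlorophenyl in place of 2-fluorophenyl gives an at least 11-fold lower number from compound 2 to compound 3 (1.06 log units; beyond the scatter). The groups that leave and enter match in heavy-atom count and in their count of hydrogen-bond donors and acceptors, and differ only in the halogen and where it sits on the phenyl ring, so a change confined to these two features is enough to move the read-out beyond the scatter. The true size of the step stays open, because compound 2 has a limit and not a number: the limit of > 20000 nM in this assay, at which 1 of the 3 values shown sits.

The single step changes the halogen and its place together, so the compounds shown do not separate the two; 2-chlorophenyl and 4-fluorophenyl on this same aniline arrangement would each isolate one of them. On these data alone, it also remains open whether the read-out depends on a halogen at all, or whether a 4-methylphenyl or 4-methoxyphenyl group at this position would serve equally well.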